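Swapping Methoxy Groups for Methyls on the Aryl Urea

The compounds below may be only part of what the source reports. "The series", "measured", "known", "first", "only" and "open" are said of these compounds alone.

Three ureas share one long unsaturated chain and differ only in the aromatic group attached to the amide-type nitrogen. In an assay on microsomes from intestinal mucosa for inhibition of acyl-CoA:cholesterol acyltransferase (Oryctolagus cuniculus) (a lower number here means a stronger inhibitor, a higher number a weaker inhibitor), compound 1 `CCCCCCCC/C=C\CCCCCCCCNC(=O)Nc1ccccc1` reaches only the limit of the assay, > 5000 nM, so no number is known for it. Compound 2 `CCCCCCCC/C=C\CCCCCCCCNC(=O)Nc1c(C)cc(C)cc1C` gives 2900 nM in this assay. Compound 3 `CCCCCCCC/C=C\CCCCCCCCNC(=O)Nc1ccc(OC)cc1OC` gives 5400 nM, the higher of the two real numbers, and its nearest neighbour is compound 2, since a 1.9-fold higher number from compound 2 to compound 3 (0.27 log units; within the scatter), a gap that lies inside the scatter of repeat measurements and so cannot order the two. The step of an at least 1.7-fold lower number from compound 1 to compound 2 (0.23 log units; that floor lies within the scatter) is likewise small, and a step that the limit leaves unreadable from compound 1 to compound 3 because of the limit of > 5000 nM in this assay, at which 1 of the 3 values shown sits.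

Compound 4 `CCCCCCCC/C=C\CCCCCCCCNC(=O)Nc1cc(C)ccc1C` is the next variation: 2,5-dimethylphenyl in place of 2,4-dimethoxyphenyl on an amide-type nitrogen. Among the measured compounds shown here, the one measured exchange of methyls against methoxy groups, a 1.9-fold higher number from compound 2 to compound 3 (0.27 log units; within the scatter), stayed within the scatter, so the change from compound 3 to compound 4 is expected to give a 1.5-fold lower number from compound 3 to compound 4 (0.19 log units; within the scatter), no real movement. Compound 4 is therefore estimated at 3500 nM, within a range of 1500 nM to 9000 nM in this assay.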

Compound 4, half-maximal inhibitory concentration: 4500 nM
Compound 4: middle estimate off by 1.3-fold (0.11 log units), on the low side; the measured number falls inside the stated range.
By their numbers in this assay, from the lowest: compounds 2, 4 and 3 (each within the scatter of the next).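

The exchange of 2,4-dimethoxyphenyl for 2,5-dimethylphenyl on the amide-type nitrogen removes the oxygen atoms and the hydrogen-bond acceptors of the aryl group, yet in this assay it gives only a 1.2-fold lower number from compound 3 to compound 4 (0.08 log units; within the scatter), so at this place the assay cannot tell the two groups apart. The second new comparison, with 2,5-dimethylphenyl in place of 2,4,6-trimethylphenyl, gives a 1.6-fold higher number from compound 2 to compound 4 (0.19 log units; within the scatter), which means that compounds 2, 3 and 4 now form a set of three substituted aryl ureas, each within the scatter of the others, whichever of these groups is present. Set against the plain phenyl group, the change gives an at least 1.1-fold lower number from compound 1 to compound 4 (0.04 log units; that floor lies within the scatter), and this step has only a floor and no true size because of the following: the limit of > 5000 nM in this assay, at which 1 of the 4 values shown sits.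

As far as these compounds go, how far compound 1 truly lies from the substituted ureas stays unknown. From the compounds shown here alone, it also remains open whether an aryl group carrying a carboxylic acid or an amine, or a shorter chain in place of the long unsaturated one, would move the number beyond the scatter.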